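Quinoxaline-type diamines: aryl substituent at the ring carbon

The source may hold more compounds than are shown below. What is called first, only, known or untested is meant among the compounds shown, and "the series" means these compounds.

Measured so far:
Compound 1 `Nc1cc(N)c2nc(-c3ccccc3)c(NCc3ccc(Cl)c(Cl)c3)nc2c1` gives < 100000 nM in a functional assay on MOLT-4 cells (Homo sapiens) for inhibition, read by sulforhodamine B assay, with a stated time of 48 h (on this read-out lower numbers stand for higher toxicity in this test and higher numbers for lower toxicity in this test), a limit of the assay.
Compound 2 `COc1ccc(CNc2nc3cc(N)cc(N)c3nc2-c2ccccc2)cc1OC` gives < 100000 nM in this assay, again a limit of the assay.
Compound 3 `Nc1cc(N)c2nc(-c3ccccc3)c(NCc3ccc(F)cc3)nc2c1` gives < 100000 nM in this assay, also a limit of the assay.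

All three measured values sit at the same limit, so none of the steps among them can be read: a step that the two limits leave unreadable from compound 1 to compound 2, a step that the two limits leave unreadable from compound 1 to compound 3 and a step that the two limits leave unreadable from compound 2 to compound 3 are each unreadable in size and direction. Compound 3 therefore stands nowhere distinct on these numbers; it shares the limit of < 100000 nM in this assay, at which 3 of the 3 values shown sit, with the other two.

The unmeasured compound 4 `Nc1cc(N)c2nc(-c3ccccc3)c(Sc3ccc(Cl)c(Cl)c3)nc2c1` differs from compound 3 in one place: (3,4-dichlorophenyl)sulfanyl in place of (4-fluorobenzyl)amino on an aromatic carbon. For the measured compounds named here, no measured step bears on this change, since every step involved only the aryl part of the benzylamino group and none of them was readable. What the data do show is that three different aryl groups at this position all left toxicity beyond the reach of the assay.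

On that basis compound 4 is expected to behave in the same way, with an estimated value of 60000 nM in this assay, within 15000 nM to 100000 nM, and the step that the limit leaves unreadable from compound 3 to compound 4 is expected to remain unreadable against the limit.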

Compound 4, concentration lethal to 50% of the cells: < 100000 nM
Compound 4 gave a limit, no number; the forecaster's own chance of this, stated with the estimate: 70%; the middle value lies beyond the limit too.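

No new step can be read between compound 3 and compound 4, since both values are limits of the assay and not numbers: the limit of < 100000 nM in this assay, at which 4 of the 4 values shown sit.

The compounds shown leave open what number compound 1, compound 2, compound 3 and compound 4 would each give in this assay, and so whether (3,4-dichlorophenyl)sulfanyl in place of (4-fluorobenzyl)amino makes any difference.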